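Cyclopropyl in place of hydrogen on a ring amine

The source may hold more compounds than are shown below. What is called first, only, known or untested is meant among the compounds shown, and "the series" means these compounds.

Compound 1 `CC(C)(C)c1cc(NC(=O)Nc2ccc(NC(=O)c3ccc(OC4CCN(C(C)(C)C)CC4)cn3)cc2)no1`: 15 mL/min/kg
Compound 2 `CC(C)(C)c1cc(NC(=O)Nc2ccc(NC(=O)c3ccc(OC4CCNCC4)cn3)cc2)no1`: 22.1 mL/min/kg

In an in vivo ADME assay on the whole organism (plasma, strain Sprague-Dawley) for pharmacokinetics, with Rattus norvegicus as the target, read by LC-MS (a higher number here means faster removal of the compound, a lower number slower removal), compound 2 gives 22.1 mL/min/kg, which lies within the scatter of compound 1 at 15 mL/min/kg. Neither compound can therefore be set apart from the other on these numbers.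

Compound 3 `CC(C)(C)c1cc(NC(=O)Nc2ccc(NC(=O)c3ccc(OC4CCN(C5CC5)CC4)cn3)cc2)no1` carries cyclopropyl in place of hydrogen on an amine nitrogen in a ring.

Going by the values given here, one measured step bears on this change, since it concerns the same nitrogen, with tert-butyl giving way to hydrogen: a 1.5-fold higher number from compound 1 to compound 2 (0.17 log units; within the scatter). Among the compounds with values here, with only that small step as a guide, no change beyond the scatter is expected in this assay. The expected step is a 1.2-fold lower number from compound 2 to compound 3 (0.09 log units; within the scatter). Compound 3 is estimated at 18 mL/min/kg, with an expected range of 9 mL/min/kg to 35 mL/min/kg.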

Compound 3, clearance: 12 mL/min/kg
Compound 3: the middle estimate sits 1.5-fold (0.18 log units) above what was measured; low and high end bracket the measured number.
By their numbers in this assay, from the lowest: compounds 3, 1 and 2 (each within the scatter of the next).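

In this assay the ring nitrogen has now been seen with hydrogen, tert-butyl and cyclopropyl, and cyclopropyl in place of hydrogen gives a 1.8-fold lower number from compound 2 to compound 3 (0.27 log units; within the scatter) while cyclopropyl in place of tert-butyl gives a 1.3-fold lower number from compound 1 to compound 3 (0.10 log units; within the scatter) on the same nitrogen. Compound 3 therefore cannot be set apart from compound 1 or compound 2, and a small carbon ring on this nitrogen adds a second group, alongside tert-butyl, that leaves clearance within the scatter of the free amine. Nothing measured here speaks to why these three compounds sit so close together.

From the compounds shown here alone, whether an acetyl group, a longer alkyl chain or a chain ending in a carboxylic acid on this nitrogen would move clearance beyond the scatter stays open. So does whether these groups would behave the same way on a different core.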